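Methoxy for Ethyl on the Core: a Stability Outlook

The source may hold more compounds than are shown below. What is called first, only, known or untested is meant among the compounds shown, and "the series" means these compounds.

Compound 1 `CCc1nc(-c2ccc(Cl)cc2Cl)c(CC)nc1NC(CC)CC` gives 0.283 h in an in vitro ADME assay on microsomes (Homo sapiens) for metabolic stability; a higher number here means that the compound lasts longer, a lower number that the compound disappears faster.
Compound 2 `CCc1nc(-c2ccc(OC)cc2C(F)(F)F)c(CC)nc1NC(CC)CC` gives 0.2 h in this assay.
Compound 3 `CCc1nc(-c2ccc(OC(F)(F)F)cc2OC)c(CC)nc1NC(CC)CC` gives 0.217 h in this assay.

All three compounds share one core and differ only in the aryl substituents, and their half-lives sit close together. Compound 3 falls in the middle of the three numbers: its nearest neighbour is compound 2 and its furthest is compound 1, and both gaps lie within the scatter, so the three compounds cannot be told apart on these data.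

Compound 4 `CCc1nc(-c2ccc(OC(F)(F)F)cc2OC)c(OC)nc1NC(CC)CC` is the next compound, not yet measured. It differs from compound 3 in the core rather than the aryl ring: methoxy in place of ethyl on an aromatic carbon. Among the measured compounds shown here, no measured pair in this set shows a change of this kind, so there is no step to lean on. The three aryl variations changed nothing beyond the scatter, and the step of a 1.0-fold higher number from compound 3 to compound 4 (0.01 log units; within the scatter) is expected to be small, with no direction preferred. Compound 4 is therefore estimated at 0.22 h, within a range from 0.1 h to 0.5 h.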

Compound 4, half-life: 0.867 h
Estimate against measurement, compound 4: 3.9-fold (0.60 log units) below; measured number above the stated range.
By their numbers in this assay, from the lowest: compounds 2, 3 and 1 (each within the scatter of the next); then compound 4.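

In this assay the exchange of ethyl for methoxy on the aromatic carbon next to the ring nitrogen gives a 4.0-fold higher number from compound 3 to compound 4 (0.60 log units; beyond the scatter) and so marks this core position as one where a single change moves the half-life beyond the scatter, whereas the numbers for compound 1, compound 2 and compound 3 stay within the scatter of one another. The exchange puts an oxygen in place of a carbon and brings in a hydrogen-bond acceptor, with no net charge on either group. No supporting measurement is available to say why the half-life rises.

This single pair leaves open whether the same exchange would carry over to the aryl groups of compound 1 or compound 2. From the compounds shown here alone, how an ethoxy group, a chlorine atom or an amine would behave at this position also remains open.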